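Bromo to methyl on the anilide of compound 3

This account rests on a few compounds, and the source may have more. Where it says the series, first, only, none or still open, it means among the compounds named here.

The series shares one core, seen in compound 1 `Cc1nc2c(F)cc(-c3nc(Nc4ccc(NC(=O)C5(C(=O)Nc6ccc(F)cc6)CC5)cc4)ncc3F)cc2n1C(C)C`, and is followed in a functional assay on HeLa cells (Homo sapiens) for antiproliferative activity, read by CCK-8 assay, with a stated time of 72 h; a lower number here means a stronger inhibitor, a higher number a weaker inhibitor. Compound 1 gives 191 nM. Compound 2 `Cc1ccc(NC(=O)C2(C(=O)Nc3ccc(Nc4ncc(F)c(-c5cc(F)c6nc(C)n(C(C)C)c6c5)n4)cc3)CC2)cc1` carries a methyl where compound 1 carries a fluoro; in this assay compound 2 gives 71.5 nM, so that a 2.7-fold lower number from compound 1 to compound 2 (0.43 log units; beyond the scatter). Compound 3 `Cc1nc2c(F)cc(-c3nc(Nc4ccc(CNC(=O)C5(C(=O)Nc6ccc(Br)cc6)CC5)cc4)ncc3F)cc2n1C(C)C` gives 330 nM, the highest of the three numbers: its gap to compound 1 lies within the scatter, while compound 2 sits clearly lower.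

Compound 4 `Cc1ccc(NC(=O)C2(C(=O)NCc3ccc(Nc4ncc(F)c(-c5cc(F)c6nc(C)n(C(C)C)c6c5)n4)cc3)CC2)cc1` differs from compound 3 in one place: methyl in place of bromo on an aromatic carbon. Among the measured compounds shown here, no measured step swaps bromo for methyl directly. For the measured compounds named here, the one step that bears on it is the swap of a halogen on the same anilide ring for a methyl, the step from compound 1 to compound 2, which gave a modest but clear fall in the number. By that analogy, a move from bromo to methyl in compound 4 is expected to lower the number by a similar, modest amount, without certainty that it clears the scatter. The step is therefore estimated as a 2.2-fold lower number from compound 3 to compound 4 (0.34 log units; beyond the scatter), and compound 4 is expected to give about 150 nM, within a range from 60 nM to 400 nM.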

Compound 4, half-maximal inhibitory concentration: 252 nM
Compound 4: the middle estimate sits 1.7-fold (0.23 log units) below what was measured, within the range that was stated.
By their numbers in this assay, from the lowest: compound 2; then compounds 1, 4 and 3 (each within the scatter of the next).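

In this assay, the change from 4-bromophenyl to 4-methylphenyl gives a 1.3-fold lower number from compound 3 to compound 4 (0.12 log units; within the scatter), so on this ring position bromo and methyl cannot be told apart by their numbers. The earlier halogen-to-methyl swap gave a 2.7-fold lower number from compound 1 to compound 2 (0.43 log units; beyond the scatter), but that step replaced fluoro rather than bromo, in a pair that also differs elsewhere in the molecule from compound 3 and compound 4, so a methyl here does not lower the number clearly in every setting shown. Nothing available accounts for the difference between these two steps.

The compounds shown leave open whether a methoxy group, an amine or a carboxylic acid at this place on the ring would move the number beyond the scatter, or whether this position tolerates such changes as it does the swap of bromo for methyl. Among the compounds shown here, they also leave open whether the size of the step depends on the halogen that leaves or on the rest of the molecule, since the fluoro and bromo swaps are seen only in different molecules.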